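This account rests on a few compounds, and the source may have more. Where it says the series, first, only, none or still open, it means among the compounds named here.

Of the compounds shown here, three built on one shared core have been measured in a functional assay on SW480 cells (Homo sapiens) for cytotoxicity, read by MTT assay, with a stated time of 4 days; a lower number here means a stronger inhibitor, a higher number a weaker inhibitor. For compound 1 `C=C1C[C@]23C[C@@]1(O)CC[C@@H]2c1cccc(C)c1[C@@H]3Cn1cc(-c2ccc(C)cc2)nn1` the result is only a limit of the assay, > 20000 nM. For compound 2 `C=C1C[C@]23C[C@@]1(O)CC[C@H]2c1cc(Br)c(O)c(C)c1[C@@H]3Cn1cc(-c2ccccn2)nn1` the result is likewise a limit, > 20000 nM. Compound 3 `C=C1C[C@]23C[C@@]1(O)CC[C@H]2c1ccc(O)c(C)c1[C@@H]3Cn1cc(-c2ccccn2)nn1` also returns only a limit, > 20000 nM. Within the data shown here, the single one-place step among them, hydrogen in place of bromo on an aromatic carbon, is a step that the two limits leave unreadable from compound 2 to compound 3; its size cannot be read, since (the limit of > 20000 nM in this assay, at which 3 of the 3 values shown sit). Compound 2 therefore stands on no number at all, only on a limit, as do the other two.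

Compound 4 `C=C1C[C@]23C[C@@]1(O)CC[C@H]2c1cc(Br)c(O)c(C)c1[C@@H]3Cn1cc(-c2ccc(F)cc2)nn1` differs from compound 2 in one place: 4-fluorophenyl in place of pyridin-2-yl on an aromatic carbon. Among the measured compounds shown here, no measured step touches this part of the molecule, so nothing shows how large its effect could be. For the measured compounds named here, what is known is that every compound so far, whatever group sits on the five-membered aromatic ring with 3 nitrogen, returns only a limit, as the limit of > 20000 nM in this assay, at which 3 of the 3 values shown sit, records. The step from compound 2 to compound 4 is therefore expected to be a step that the limit leaves unreadable from compound 2 to compound 4, that is, no readable change. Compound 4 is estimated at 30000 nM in this assay, within a range from 12000 nM to 80000 nM, and most probably as yet another limit.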

Compound 4, half-maximal inhibitory concentration: > 20000 nM
Compound 4: no number, only a limit; the forecaster's own chance of this, stated with the estimate: 85%; the middle value does not contradict the limit.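

Compound 4, like compound 2, gives only a limit in this assay, so no step can be read from the change of pyridin-2-yl to 4-fluorophenyl: the limit of > 20000 nM in this assay, at which 4 of the 4 values shown sit. The compounds shown leave open which change to the shared core or its groups, if any, would give a real number in this assay.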